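Vero cytotoxicity notes on a shared core, compounds 1 to 4

The compounds below may be only part of what the source reports. "The series", "measured", "known", "first", "only" and "open" are said of these compounds alone.

Compound 1 `O=c1nc(N2CCN(NCC3CCCCC3)CC2)sc2c([N+](=O)[O-])cc(C(F)(F)F)cc12` gives 29.3 ug/mL in an ADME assay on Vero cells (Chlorocebus sabaeus) for cytotoxicity, read by MTT assay, with a stated time of 72 h; on this read-out lower numbers stand for higher toxicity in this test and higher numbers for lower toxicity in this test.
Compound 2 `CN(CC1CCCCC1)N1CCN(c2nc(=O)c3cc(C(F)(F)F)cc([N+](=O)[O-])c3s2)CC1` gives only a limit of this assay, > 64 ug/mL.
Compound 3 `O=c1nc(N2CCN(NCc3ccc(Cl)cc3)CC2)sc2c([N+](=O)[O-])cc(C(F)(F)F)cc12` likewise gives only a limit, > 64 ug/mL.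

Compound 2 therefore stands at the top of the numbers shown, on (the limit of > 64 ug/mL in this assay, at which 2 of the 3 values shown sit), with no number of its own. Within the data shown here, the one readable step into it is an at least 2.1-fold higher number from compound 1 to compound 2 (0.33 log units; beyond the scatter), a methyl in place of hydrogen on an amine nitrogen. Compound 4 `Cc1ccc(CNN2CCN(c3nc(=O)c4cc(C(F)(F)F)cc([N+](=O)[O-])c4s3)CC2)cc1` differs from compound 2 as follows: (4-methylbenzyl)amino in place of (cyclohexylmethyl)(methyl)amino on an amine nitrogen in a ring. Among the measured compounds shown here, two measured steps bear on this change. The step of an at least 2.1-fold higher number from compound 1 to compound 3 (0.33 log units; beyond the scatter) shows that an aromatic ring in place of the cyclohexyl carried the value to the limit; the step that the two limits leave unreadable from compound 2 to compound 3 runs between two limits and gives no size. Compound 4 keeps the aromatic ring of compound 3 but returns the hydrogen on the amine nitrogen that compound 1 carries, so the outcome is uncertain. Compound 4 is expected to sit near the limit again, with the step of an at least 1.1-fold lower number from compound 2 to compound 4 (0.06 log units; that floor lies within the scatter) expected to be small or not readable. The estimate for compound 4 is 55 ug/mL, expected between 25 ug/mL and 100 ug/mL.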

Compound 4, half-maximal cytotoxic concentration: > 64 ug/mL
Compound 4 gave a limit, no number; the forecaster's own chance of this, stated with the estimate: 55%; middle value at least 1.1-fold (0.06 log units) from the limit.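

Compound 4 gives only a limit in this assay, and the series gathers further at that one limit: the limit of > 64 ug/mL in this assay, at which 3 of the 4 values shown sit.

With cyclohexyl replaced by 4-methylphenyl on the saturated chain carbon bound to the amine nitrogen, the result is an at least 2.1-fold higher number from compound 1 to compound 4 (0.33 log units; beyond the scatter), so the rise seen with compound 3 does not need a chloro group on the aromatic ring, and the hydrogen on the amine nitrogen, present in compound 1, compound 3 and compound 4 alike, does not bring the value back down once the aromatic ring is there. The steps that link compound 4 with compound 2 and compound 3 run between limits and cannot be read, so methyl against chloro on the aromatic carbon has no size here.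

From the compounds shown here alone, the true values of compound 2, compound 3 and compound 4 remain unknown, which leaves any order among them open. Also open, going by these compounds, is whether a carboxylic acid or a nitrile in place of the methyl on the aromatic carbon, or a longer chain on the amine nitrogen, would give a readable number rather than a limit.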